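The source may report more compounds than this note shows. Statements on the series, on what has been measured and on what is new or still open speak of the compounds shown alone.

Among the compounds with values here, the compounds measured so far in an ADME assay on HepG2 cells (Homo sapiens) for cytotoxicity, with a stated time of 72 h (on this read-out higher numbers stand for an effect only at larger amounts of compound and lower numbers for an effect already at smaller amounts), are these.

- Compound 1 (`Cc1cc(NC(=O)Nc2ccc(C)c(Cl)c2)c2ccccc2n1`) gives > 25000 nM as a limit of the assay
- Compound 2 (`Cc1cc(NC(=O)Nc2ccc(Cl)c(Cl)c2)c2ccccc2n1`) gives 17000 nM as a number
- Compound 3 (`COc1ccc(NC(=O)Nc2cc(C)nc3ccccc23)cc1OC`) gives > 25000 nM as a limit of the assay

Compound 3 stands at the limit of > 25000 nM in this assay, at which 2 of the 3 values shown sit, and so has only a limit, not a number. Compound 4 (`COc1ccc(NC(=O)Nc2cc(C)nc3ccccc23)cc1Cl`) carries chloro in place of methoxy on an aromatic carbon ortho to a methoxy group and meta to a large group. Within the data shown here, one measured step bears on this change, since it also brings in chloro on an aromatic carbon, there in place of methyl. That step is an at least 1.4-fold lower number from compound 1 to compound 2 (0.16 log units; that floor lies within the scatter) and it is only a loose guide, as methoxy rather than methyl leaves in compound 4. Among the measured compounds shown here, compound 2 (17000 nM) is the one chloro compound with a number, so a small move towards lower numbers is expected, probably not clearly beyond the scatter. The estimated step is an at least 1.2-fold lower number from compound 3 to compound 4 (0.09 log units; that floor lies within the scatter) and the assay may well report only a limit again. For compound 4 the expected value is 20000 nM with an estimated range from 10000 nM to 35000 nM in this assay as the outcome.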

Compound 4, half-maximal effective concentration: > 25000 nM
Compound 4 gave a limit, no number (the forecaster's own chance of this, stated with the estimate: 50%); at least 1.2-fold (0.09 log units) between middle value and limit.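

Placing chloro on this aromatic carbon, ortho to a methoxy group, is not enough by itself to bring a number in this assay, since compound 4 gives only a limit of the assay. Within the data shown here, the one readable comparison is an at least 1.4-fold higher number from compound 2 to compound 4 (0.16 log units; that floor lies within the scatter), so methoxy in place of chloro at this position gives a step whose printed floor does not go beyond the usual scatter, and its true size could be larger. The steps to compound 4 from compound 3 and from compound 1 cannot be read, because both ends of each are limits: the limit of > 25000 nM in this assay, at which 3 of the 4 values shown sit.

Among these compounds, compound 2 remains the only compound with a number, so how far the other three lie from it, and from each other, stays open. Also open, on these data alone, is whether a different group at this position, such as an amine or a carboxylic acid in place of the methoxy group, would give a number in this assay and how it would compare with chloro.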